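A few compounds are considered here, and "the series" means these few. Any claim that something is new, unique, unknown or untested is made for them only; others in the source may bear on it.

Measured compounds:
- compound 1 `CN1CCN(c2ccc(Nc3ncc4nc(Nc5ccc(F)cc5)n([C@@H]5CCN(C(=O)CO)C5)c4n3)cc2)CC1`: "not determined" (no result reported)
- compound 2 `CN1CCN(c2ccc(Nc3ncc4nc(Nc5ccc(F)cc5)n([C@H]5CCCN(S(=O)(=O)C6CC6)C5)c4n3)cc2)CC1`: 1340 nM
- compound 3 `CN1CCN(c2ccc(Nc3ncc4nc(Nc5ccc(F)cc5)n([C@H]5CCCC(NC(=O)OC(C)(C)C)C5)c4n3)cc2)CC1`: "not determined" (no result reported)

Three compounds share one core, but only compound 2 carries a number. In a functional assay on A-431 cells (Homo sapiens) for antiproliferative activity, read by MTT assay, with a stated time of 72 h (a higher number here means a weaker inhibitor, a lower number a stronger inhibitor), compound 2 gives 1340 nM, so it stands alone, with compound 1 and compound 3 offering no value to compare against. Compound 4 `CN1CCN(c2ccc(Nc3ncc4nc(Nc5ccc(F)cc5)n(-c5cccc(NC(=O)CO)c5)c4n3)cc2)CC1` is the next step: 3-(((hydroxymethyl)carbonyl)amino)phenyl in place of 1-(cyclopropylsulfonyl)piperidin-3-yl on an aromatic nitrogen. Among the measured compounds shown here, no measured pair tells how such a swap moves the number, so the expectation rests on compound 2 alone. The step from compound 2 to compound 4 is expected to be modest, a 1.3-fold lower number from compound 2 to compound 4 (0.13 log units; within the scatter), not clearly beyond the usual scatter. Compound 4 is therefore estimated at 1000 nM, within a range from 250 nM to 4000 nM.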

Compound 4, half-maximal inhibitory concentration: 1670 nM
Beside the measured number, compound 4's estimate is 1.7-fold (0.22 log units) below it, within the range that was stated.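

Replacing 1-(cyclopropylsulfonyl)piperidin-3-yl with 3-(((hydroxymethyl)carbonyl)amino)phenyl on the aromatic nitrogen gives a 1.2-fold higher number from compound 2 to compound 4 (0.10 log units; within the scatter) in this assay, so this position can take either group with no clear change in the number. A non-aromatic ring with a defined stereocentre and an aromatic ring with none therefore read alike here. Nothing measured on these compounds explains this result.

On these data alone, the ring and its side chain change together, so their separate contributions remain unknown. A phenyl ring carrying an amine or a carboxylic acid at this position remains untested among the compounds shown.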